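Replacing Carbamoyl with Benzamido on the Shared Core

The compounds below may be only part of what the source reports. "The series", "measured", "known", "first", "only" and "open" are said of these compounds alone.

Compound 1 `Cc1cc(C(N)=O)nn1Cc1cc(Cl)ccc1OCc1ccccc1` gives 3.7 in a physicochemical assay for lipophilicity, at pH 7.4; on this read-out higher numbers stand for higher lipophilicity and lower numbers for lower lipophilicity.
Compound 2 `Cc1cc(C(=O)NC(C)C)nn1Cc1cc(Cl)ccc1OCc1ccccc1` reaches only a limit of this assay, > 3.7.
Compound 3 `Cc1cc(C(=O)NCc2ccccc2)nn1Cc1cc(Cl)ccc1OCc1ccccc1` likewise reaches only a limit of this assay, > 3.7.

Compound 1 thus stands at the only number shown; the two other values are limits, as the limit of > 3.7 in this assay, at which 2 of the 3 values shown sit, records. The change to compound 4 `Cc1cc(NC(=O)c2ccccc2)nn1Cc1cc(Cl)ccc1OCc1ccccc1` is benzamido in place of carbamoyl on an aromatic carbon. Within the data shown here, two measured steps bear on it: a number no lower from compound 1 to compound 2 (the limit leaves the size open), where isopropyl replaces hydrogen on an amide-type nitrogen, and a number no lower from compound 1 to compound 3 (the limit leaves the size open), where benzyl replaces hydrogen there. Both put carbon groups onto the amide and both ran no lower, though their size cannot be read. The step that the two limits leave unreadable from compound 2 to compound 3 is unreadable because both ends are limits. Adding a benzene ring on the amide in compound 4 is therefore expected to raise lipophilicity, roughly a number 1.00 log units higher from compound 1 to compound 4 (beyond the scatter). Compound 4 is estimated at 4.7, within 4 to 5.4, and most likely this assay will again report only a limit.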

Compound 4, distribution coefficient: > 3.7
Compound 4: only a limit was reported; the forecaster's own chance of this, stated with the estimate: 85%; the middle value does not contradict the limit.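

In this assay, benzamido in place of carbamoyl gives a number no lower from compound 1 to compound 4 (the limit leaves the size open) on this aromatic carbon, so the direction seen so far is kept but its size remains hidden. The earlier compounds shown here carried their added carbon groups on a carbamoyl nitrogen, whereas in compound 4 the amide nitrogen itself sits on the aromatic carbon and carries the benzene ring through its carbonyl, and that change also ran no lower. Compound 4 gives only a limit, and the steps from compound 2 and compound 3 to compound 4 cannot be read: the limit of > 3.7 in this assay, at which 3 of the 4 values shown sit.

From the compounds shown here alone, how much higher compound 2, compound 3 and compound 4 lie than compound 1, if at all, and how they rank among themselves, stay open. Also open, going by these compounds, is what the reading would be with a smaller acetamido, an amine or a carboxylic acid on this aromatic carbon, and whether any of these would return a number instead of a limit.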